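Replacing the sulfonamide nitrogen with an isobutyl chain

The source may hold more compounds than are shown below. What is called first, only, known or untested is meant among the compounds shown, and "the series" means these compounds.

Compound 1 `CCN(CC)S(=O)(=O)c1ccc(S(=O)(=O)N2CCC[C@@H](C(=O)N3CCC(F)(F)CC3)C2)cc1` is the more potent of the two measured entries in a functional assay on MIA PaCa-2 cells (Homo sapiens) for inhibition, read by MTT assay, with a stated time of 7 days (on this read-out higher numbers stand for weaker inhibition and lower numbers for stronger inhibition), where compound 1 gives 16 nM. Within the data shown here, its only measured neighbour, compound 2 `CCN(CC)S(=O)(=O)c1ccc(S(=O)(=O)N2CCC[C@@H](C(=O)N3CCOCC3)C2)cc1`, gives 350 nM in this assay, and the change from one to the other, morpholin-4-yl in place of 4,4-difluoropiperidin-1-yl on a carbonyl carbon, produces a 22-fold higher number from compound 1 to compound 2 (1.34 log units; beyond the scatter). Compound 3 `CC(C)CS(=O)(=O)c1ccc(S(=O)(=O)N2CCC[C@@H](C(=O)N3CCC(F)(F)CC3)C2)cc1` keeps the 4,4-difluoropiperidin-1-yl amide of compound 1 and differs from it elsewhere: isobutyl in place of diethylamino on a sulfonyl sulfur. Among the measured compounds shown here, no measured step touches the sulfonyl sulfur; the single step available concerns the carbonyl carbon at the far end of the shared core and so says nothing directly about this exchange. For the measured compounds named here, with no comparable precedent, the most defensible expectation is that compound 3 stays near compound 1, with a step of a 1.6-fold higher number from compound 1 to compound 3 (0.19 log units; within the scatter) expected to lie within the scatter but with wide uncertainty in either direction. Compound 3 is therefore estimated at 25 nM in this assay, within a range of 6 nM to 120 nM.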

Compound 3, half-maximal inhibitory concentration: 80 nM
Estimate against measurement, compound 3: 3.2-fold (0.51 log units) below; low and high end bracket the measured number.
By their numbers in this assay, from the lowest: compound 1; then compound 3; then compound 2.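

In this assay the sulfonyl sulfur turns out to be a position that responds to change: isobutyl in place of diethylamino gives a 5.0-fold higher number from compound 1 to compound 3 (0.70 log units; beyond the scatter) and so counts as a modest step, but a real one. Among these compounds, until now the only readable step lay at the carbonyl carbon, with a 22-fold higher number from compound 1 to compound 2 (1.34 log units; beyond the scatter) and so, with this result, changes at both the carbonyl carbon and the sulfonyl sulfur lead away from compound 1 to a higher number. Nothing measured explains why isobutyl and diethylamino differ in this way.

From the compounds shown here alone, it remains open whether other groups on the sulfonyl sulfur, such as pyrrolidin-1-yl, piperidin-1-yl or a shorter chain like ethyl, would stay nearer to compound 1 or move further away, and so whether the nitrogen of diethylamino or the shape of the chain is what separates compound 1 from compound 3. The compounds also leave open whether the two changes add up, which a compound joining isobutyl on the sulfonyl sulfur with the morpholin-4-yl group on the carbonyl carbon would show.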